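The source may hold more compounds than are shown below. What is called first, only, known or untested is meant among the compounds shown, and "the series" means these compounds.

- Compound 1 `Cc1cc(C)cc(CN2CCc3ncn(COCc4ccccc4)c3/C(=C/c3ccccc3)C2=O)c1` gives 52600 nM
- Compound 2 `COc1ccc(CN2CCc3ncn(COCc4ccccc4)c3/C(=C/c3ccccc3)C2=O)cc1` gives 71600 nM

Both compounds were tested in a functional assay on BGC-823 cells (Homo sapiens) for inhibition, read by MTT assay, with a stated time of 72 h; on this read-out lower numbers stand for stronger inhibition and higher numbers for weaker inhibition. Only these two numbers exist so far, and compound 1 cannot be separated from compound 2, so it holds no distinct place in this small set.

Compound 3 `O=C1/C(=C\c2ccccc2)c2c(ncn2COCc2ccccc2)CCN1Cc1ccc2ccccc2c1` keeps the core of compound 1 and changes one group (naphthalen-2-yl in place of 3,5-dimethylphenyl on a saturated chain carbon bound to an amide-type nitrogen in a ring). Put simply, naphthalen-2-yl replaces 3,5-dimethylphenyl on a saturated chain carbon bound to an amide-type nitrogen in a ring.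

Among the compounds with values here, one measured step bears on this change, because it alters the same place: a 1.4-fold higher number from compound 1 to compound 2 (0.13 log units; within the scatter). There, 4-methoxyphenyl replaced 3,5-dimethylphenyl. Within the data shown here, this single swap is thin evidence, and no measured compound yet carries naphthalen-2-yl. No step beyond the scatter is therefore expected in this assay, in either direction, although the uncertainty is wide. The estimated change is small (a 1.1-fold lower number from compound 1 to compound 3 (0.02 log units; within the scatter)). For compound 3 the expected value is 50000 nM, with an estimated range of 20000 nM to 120000 nM in this assay.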

Compound 3, half-maximal inhibitory concentration: 93300 nM
The estimate for compound 3 lay 1.9-fold (0.27 log units) below the measured number; low and high end bracket the measured number.
By their numbers in this assay, from the lowest: compounds 1, 2 and 3 (each within the scatter of the next).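

At this place, on a saturated chain carbon bound to an amide-type nitrogen in a ring, the series now includes a group with 2 six-membered aromatic rings of carbon only. In this assay, naphthalen-2-yl in place of 3,5-dimethylphenyl gives a 1.8-fold higher number from compound 1 to compound 3 (0.25 log units; within the scatter), and in place of 4-methoxyphenyl it gives a 1.3-fold higher number from compound 2 to compound 3 (0.11 log units; within the scatter). Both steps lie within the usual scatter, so going from one aromatic ring to two, with 10 heavy atoms instead of 8, does not separate compound 3 from either earlier compound, and no order can be set among the three; nothing measured here explains why these numbers lie so close together.

All three groups shown at this place are built on aromatic carbon rings, so it remains open whether a different kind of group, such as an aminoethyl chain, a carboxylic acid or a plain butyl chain, would move the number beyond the scatter. Also open, as far as these compounds go, is whether a change elsewhere on the shared core would do more than the swaps at this place have done.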